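Swapping the amine tail in a weak caspase-8 inhibitor series

A few compounds are considered here, and "the series" means these few. Any claim that something is new, unique, unknown or untested is made for them only; others in the source may bear on it.

Measured so far:
Compound 1, `CCC(C(=O)N[C@@H](CC(=O)O)C(=O)CSCc1ccccc1)n1ccnc(NCC2COc3ccccc3O2)c1=O`: 8220 nM
Compound 2, `CCCCCCN(C)CNCC(=O)[C@H](CC(=O)O)NC(=O)C(CC)n1ccnc(NCc2nonc2C)c1=O`: > 10000 nM
Compound 3, `CCCCCCN(C)CNCC(=O)[C@H](CC(=O)O)NC(=O)C(CC)n1cc(C(C)(CC)CC)nc(NCc2nonc2C)c1=O`: > 10000 nM

For the measured compounds named here, in an assay for inhibition of Caspase-8 (Homo sapiens) (on this read-out higher numbers stand for weaker inhibition and lower numbers for stronger inhibition), compound 1 gives 8220 nM, the only plain number among the three. For compound 2 the result is a limit of the assay, > 10000 nM. For compound 3 the result is likewise a limit, > 10000 nM. Going by the values given here, compound 2 therefore stands at the weak end of what was measured, as the limit of > 10000 nM in this assay, at which 2 of the 3 values shown sit, shows, and the one single-point step that exists, a step that the two limits leave unreadable from compound 2 to compound 3, cannot be read because both ends are limits.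

Compound 4, `CCC(C(=O)N[C@@H](CC(=O)O)C(=O)CNCN1Cc2ccccc2C1)n1ccnc(NCc2nonc2C)c1=O`, has not yet been measured. It differs from compound 2 in one place: a group of 9 heavy atoms (8 carbon, 1 nitrogen; one five-membered non-aromatic ring with 1 hetero atom, one six-membered aromatic ring of carbon only) in place of a group of 8 heavy atoms (7 carbon, 1 nitrogen; no ring), on a saturated chain carbon bound to an amine nitrogen.

Among the compounds with values here, no measured step covers a change of this kind, so there is nothing to size an expectation against beyond the position of compound 2 itself. With compound 2 already at the limit, compound 4 is expected to remain weak, and the estimated step that the limit leaves unreadable from compound 2 to compound 4 is taken as no change beyond the scatter. Compound 4 is therefore estimated at 12000 nM, within a range from 3000 nM to 40000 nM.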

Compound 4, half-maximal inhibitory concentration: 4290 nM
Estimate against measurement, compound 4: 2.8-fold (0.45 log units) above; measured number inside the range.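

In this assay, putting the two-ring group in place of hexyl(methyl)amino, on a saturated chain carbon bound to an amine nitrogen, gives an at least 2.3-fold lower number from compound 2 to compound 4 (0.36 log units; beyond the scatter). This shows that inhibition responds to what sits at this end of the molecule, and that the tail need not be an open chain; the other step among these compounds, the addition of 1-ethyl-1-methylpropyl, cannot be read, as both of its ends are limits. The true size of the new step remains unknown because compound 2 has a limit of the assay and not a plain number: the limit of > 10000 nM in this assay, at which 2 of the 4 values shown sit.

On these data alone, it remains open whether the six-membered aromatic ring matters, or whether a plain pyrrolidine, with a five-membered ring alone, or a morpholine would serve as well as the group in compound 4, which at 4290 nM is still a weak inhibitor. As far as these compounds go, it is also open whether the same swap would lift compound 3, which carries 1-ethyl-1-methylpropyl on the core, to a readable number.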